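Removing one trifluoromethyl from the urea aryl of compound 2

The source may report more compounds than this note shows. Statements on the series, on what has been measured and on what is new or still open speak of the compounds shown alone.

Of the compounds shown here, two have numbers so far. Compound 1 `O=C(Nc1cccc(-n2cc(-c3ccncc3)c(-c3cc(O)cc(Cl)c3)n2)c1)Nc1ccc(Cl)c(Cl)c1` in a functional assay on SN12C cells (Homo sapiens) for inhibition, read by sulforhodamine B assay, with a stated time of 48 h, tested at 100 uM (a lower number here means a stronger effect, a higher number a weaker effect of the compound at the concentration tested), gives -15%. Compound 2 `COc1cc(Cl)cc(-c2nn(-c3cccc(NC(=O)Nc4cc(C(F)(F)F)cc(C(F)(F)F)c4)c3)cc2-c2ccncc2)c1` in this assay gives -61%, the lowest of the two numbers; the gap to compound 1 lies beyond the scatter. Compound 3 `COc1cc(Cl)cc(-c2nn(-c3cccc(NC(=O)Nc4cccc(C(F)(F)F)c4)c3)cc2-c2ccncc2)c1` has not yet been measured in this assay. It differs from compound 2 in one place: hydrogen in place of trifluoromethyl on an aromatic carbon. Among the compounds with values here, no step between measured compounds is available, and compound 1 differs from compound 2 in more than one place, so its number gives no direct guide. The expectation rests on the loss of one trifluoromethyl group from the urea aryl while the rest of compound 2 is kept; a step from compound 2 to compound 3 of a number 26 percentage points higher from compound 2 to compound 3 (beyond the scatter) toward a weaker effect is expected. For compound 3 in this assay the estimated value is -35%, within a range from -70% to 0%.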

Compound 3, a percentage reported as activity, at one concentration (the size of the read-out at that concentration, not a potency): -20%
Compound 3: the middle estimate sits 15 percentage points below what was measured; the measured number falls inside the stated range.
By their numbers in this assay, from the lowest: compound 2; then compounds 3 and 1 (each within the scatter of the next).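

In this assay, the position meta to a trifluoromethyl group on the urea aryl proves sensitive to substitution: hydrogen in place of trifluoromethyl gives a number 41 percentage points higher from compound 2 to compound 3 (beyond the scatter), a large step toward a weaker effect and the first single-place change readable in this series. Since compound 3 matches compound 2 everywhere else, the step can be assigned to this one aromatic carbon, and the second trifluoromethyl is shown to matter for the size of the read-out at the concentration tested. No measurement at hand bears on the reason for a step of this size.

Still open, as far as these compounds go, is whether trifluoromethyl itself is needed here, or whether a methyl or a nitrile on the same carbon would hold the stronger effect of compound 2. Also open, from the compounds shown here alone, is whether removing the remaining trifluoromethyl of compound 3 would weaken the effect further.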